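This account rests on a few compounds, and the source may have more. Where it says the series, first, only, none or still open, it means among the compounds named here.

Among the measured compounds shown here, compound 1, `CCC(CC)C(=O)OCOC(=O)C1=C(S[C@@H]2CN[C@H](C(=O)Nc3cccc(C(=O)O)c3)C2)[C@H](C)[C@@H]2[C@@H]([C@@H](C)O)C(=O)N12`, holds the higher of the two numbers measured so far. In an ADME assay on a cell-free system (plasma, Homo sapiens) for metabolic stability, read by LC-MS, with a stated time of 60 min, at 37 degrees C, tested at 50 uM (on this read-out lower numbers stand for a less stable compound and higher numbers for a more stable compound), compound 1 gives 82%. For the measured compounds named here, compound 2, `CC(=O)O[C@H](C)[C@H]1C(=O)N2C3=C(S[C@@H]4CN[C@@H](C4)C(=O)Nc4cccc(c4)C(=O)OCOCOC3=O)[C@H](C)[C@H]12`, gives in this assay a reading of 30%, which lies well below that of compound 1 and beyond the usual scatter; the two compounds differ in several places at once, so no single step connects them. Compound 3, `CC(C)OC(=O)OCOC(=O)C1=C(S[C@@H]2CN[C@H](C(=O)Nc3cccc(C(=O)O)c3)C2)[C@H](C)[C@@H]2[C@@H]([C@@H](C)O)C(=O)N12`, differs from compound 1 in one spot only: isopropoxy in place of pentan-3-yl on a carbonyl carbon. Going by the values given here, no measured pair shows this exact change, so the size of the step cannot be read off directly. Because compound 1 gives 82%, compound 3 is expected to stay fairly stable, with a small drop that may not clear the scatter, an estimated step of a number 12 percentage points lower from compound 1 to compound 3 (beyond the scatter). Compound 3 is therefore estimated at 70%, with a likely range from 50% to 90%.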

Compound 3, percent of the compound remaining: 62%
Estimate against measurement, compound 3: 8 percentage points above; measured number inside the range.
By their numbers in this assay, from the lowest: compound 2; then compound 3; then compound 1.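

Among the compounds shown here, this is the first comparison in which only one place changes: with the rest of compound 1 kept, isopropoxy in place of pentan-3-yl on a carbonyl carbon gives a number 20 percentage points lower from compound 1 to compound 3 (beyond the scatter) in this assay. The group at this outer end of the chain therefore matters to this read-out, and a swap of a single small group is enough to move the reading beyond the usual scatter. No measurement at hand speaks to the cause of this step.

Isopropoxy differs from pentan-3-yl both in carrying an oxygen and in its number of carbons, so this one pair cannot tell which of the two differences goes with the step. An isopropyl or a pentan-3-yloxy group on the same carbonyl carbon would pull these two differences apart.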